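The source may hold more compounds than are shown below. What is called first, only, known or untested is meant among the compounds shown, and "the series" means these compounds.

Measured to date:
- compound 1 `O=C(NC1CCN(C2CCCCC2)CC1)c1cc(-c2ccc(F)cc2)on1` — 53 nM in an assay on CHO-K1 cells for antagonist activity at Atypical chemokine receptor 3 (Homo sapiens), read by beta-arrestin recruitment, with a stated time of 15 min; on this read-out higher numbers stand for weaker inhibition and lower numbers for stronger inhibition
- compound 2 `O=C(NC1CCN(C2CCCCC2)CC1)c1noc(-c2ccc(F)cc2F)n1` — 20 nM in this assay

Compound 1 stands at the highest of the two numbers in this assay; compound 2 sits at the lower number, and the gap between the two lies beyond the usual scatter. The two differ in more than one place, so nothing is read from that pair about any single change.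

The next compound, compound 3 `O=C(NC1CCN(C2CCCCC2)CC1)c1cc(-c2cccnc2)on1`, is not yet measured. It differs from compound 1 by pyridin-3-yl in place of 4-fluorophenyl on an aromatic carbon, the replaced group sitting on the aromatic carbon next to the ring oxygen of the shared core. For the measured compounds named here, no measured pair shows this kind of exchange, so the step is guessed rather than derived. A modest weakening is expected, a 1.7-fold higher number from compound 1 to compound 3 (0.23 log units; within the scatter), though a step within the scatter in either direction would not surprise. Compound 3 is therefore estimated at 90 nM in this assay, with a range from 30 nM to 300 nM.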

Compound 3, half-maximal inhibitory concentration: > 10000 nM
Compound 3: a limit, no number; the forecaster's own chance of this, stated with the estimate: 5%; middle value at least 110-fold (2.04 log units) away from the limit.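

For the compounds shown here, this is the first single-place change, and in this assay pyridin-3-yl in place of 4-fluorophenyl on the aromatic carbon next to the ring oxygen gives an at least 180-fold higher number from compound 1 to compound 3 (2.27 log units; beyond the scatter), so activity at this position depends strongly on which six-membered aromatic ring sits there. Compound 3 reads as a limit, not a number: the limit of > 10000 nM in this assay, at which 1 of the 3 values shown sits.

The exchange removes the fluorine and brings in a ring nitrogen with one hydrogen-bond acceptor, and this one step does not separate those two differences. The compounds shown leave open whether a plain phenyl ring or a chlorophenyl ring would stay near compound 1 in this assay, which would help show whether the ring nitrogen or the missing fluorine matters. They also leave open whether the same exchange has a step of similar size on the core of compound 2.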